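Swapping Hydroxy for Methylpiperazine on the Shared Core

The source may hold more compounds than are shown below. What is called first, only, known or untested is meant among the compounds shown, and "the series" means these compounds.

Measured in a functional assay on SK-OV-3 cells (Homo sapiens) for cytotoxicity; a lower number here means a stronger inhibitor, a higher number a weaker inhibitor:
compound 1 `Cc1ccc2c(O)nc(-c3ccccc3)cc2c1`: 1700 nM
compound 2 `Cc1ccc2c(O)nc(-c3ccccc3C)cc2c1`: 4270 nM
compound 3 `Cc1ccc2c(S)nc(-c3ccccc3)cc2c1`: 34700 nM; 56200 nM (2 entries)

Of the two compounds with a single number in this assay, compound 2 stands higher, at 4270 nM, and so is the weaker inhibitor of that pair. The entries of compound 3 are higher still, at 34700 nM; 56200 nM (2 entries).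

The next compound, compound 4 `Cc1ccc2c(N3CCN(C)CC3)nc(-c3ccccc3C)cc2c1`, keeps everything in compound 2 except one group: 4-methylpiperazin-1-yl in place of hydroxy on an aromatic carbon. The 4-methylpiperazin-1-yl takes the place of hydroxy on an aromatic carbon, next to the ring nitrogen.

Among the compounds with values here, the only measured step is a 2.5-fold higher number from compound 1 to compound 2 (0.40 log units; beyond the scatter), with methyl in place of hydrogen on an aromatic carbon. That methyl stays in compound 4, so this step gives only a sense of scale and says nothing direct about the new group. Compound 3 shows that the number can rise when the group at this place differs, since compound 3 gives 34700 nM; 56200 nM (2 entries), against compound 1 at 1700 nM. Within the data shown here, no measured compound carries the 4-methylpiperazin-1-yl, however, so neither direction can be favoured with confidence. The expected change is a 1.4-fold lower number from compound 2 to compound 4 (0.15 log units; within the scatter), which amounts to no firm shift, within a wide margin. For compound 4 the estimated value is 3000 nM, with an expected range of 400 nM to 20000 nM.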

Compound 4, half-maximal inhibitory concentration: 5130 nM
For compound 4 the middle estimate is 1.7-fold (0.23 log units) below the measured one; the range from low to high includes it.
By their numbers in this assay, from the lowest: compound 1; then compounds 2 and 4 (each within the scatter of the next).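

In this assay, the step from hydroxy to 4-methylpiperazin-1-yl on this aromatic carbon, next to the ring nitrogen, is a 1.2-fold higher number from compound 2 to compound 4 (0.08 log units; within the scatter). This place on the shared core therefore accepts a group with a six-membered non-aromatic ring and no hydrogen-bond donor without a shift that can be told from the scatter, at least in this one pair, and the hydroxy's donor is not needed to keep the number at this level. The place is not indifferent to every group, however, as compound 1 gives 1700 nM, while the single change at this place in compound 3 gives much higher numbers: the several entries of compound 3 in this assay, 34700 nM; 56200 nM (2 entries)

The compounds shown leave open how an open-chain amine, a methoxy group or a carboxylic acid would behave at this place, and whether the 4-methylpiperazin-1-yl would give the same picture on the core of compound 1, without the added methyl. They also leave open which part of the 4-methylpiperazin-1-yl matters, whether its ring, its second nitrogen or its terminal methyl.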